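Working notes: cytotoxicity in HEL cells, compounds 1 to 3

A few compounds are considered here, and "the series" means these few. Any claim that something is new, unique, unknown or untested is made for them only; others in the source may bear on it.

Measured so far:
compound 1 `C/C(=N\NC(=O)COc1cccc2ccccc12)c1ccccc1Br`: 20 ug/mL
compound 2 `O=C(COc1cccc2ccccc12)N/N=C/c1c(O)ccc2ccccc12`: 4 ug/mL

In an ADME assay on HEL cells (Homo sapiens) for cytotoxicity (on this read-out lower numbers stand for higher toxicity in this test and higher numbers for lower toxicity in this test), compound 1 gives 20 ug/mL and stands at the highest of the two numbers recorded, that is, the least toxic read-out seen in the pair. Compound 2 gives 4 ug/mL in the same test, a lower number that lies beyond the scatter, so compound 2 is the more toxic of the two. The two measured compounds differ in more than one place, so their pair says nothing about any single change.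

Compound 3 `C/C(=N\NC(=O)COc1cccc2ccccc12)c1ccc(O)cc1` is not yet measured. It differs from compound 1 by 4-hydroxyphenyl in place of 2-bromophenyl on a carbon with a double bond to nitrogen. Within the data shown here, no step between measured compounds covers this change, so the expectation rests on compound 1 alone and on the single change. The expected step of a 1.3-fold higher number from compound 1 to compound 3 (0.10 log units; within the scatter) is small, no larger than the scatter, with a slight lean toward a higher number, meaning lower toxicity. For compound 3 the estimate in this assay is 25 ug/mL, with a range from 8 ug/mL to 80 ug/mL.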

Compound 3, minimum cytotoxic concentration: 20 ug/mL
Compound 3: middle estimate off by 1.3-fold (0.10 log units), on the high side; measured number inside the range.
By their numbers in this assay, from the lowest: compound 2; then compounds 1 and 3 (each within the scatter of the next).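

The read-out in this assay shows no change at the digits printed from compound 1 to compound 3 (within the scatter) when 4-hydroxyphenyl takes the place of 2-bromophenyl on a carbon with a double bond to nitrogen. Among these compounds, this is the first single-place step, and it shows that, on the core of compound 1, this position accepts an exchange of bromine for oxygen, and the gain of a hydrogen-bond donor and acceptor, with no read-out change beyond the scatter. No supporting measurement accompanies the step, so the data give no cause for this outcome.

Among the compounds shown here, only this one pair of aromatic groups has been read at the position, so it remains open whether the read-out would also hold with an amine or a carboxylic acid on the ring, or with a longer saturated chain in place of the ring. On these data alone, compound 2 is joined to neither compound 1 nor compound 3 by a single-place step, so whether the same exchange behaves alike on its core also stays open.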